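Swapping a Hydroxy for a Methyl on the Aryl Arm

This account rests on a few compounds, and the source may have more. Where it says the series, first, only, none or still open, it means among the compounds named here.

Three compounds built on one shared core were examined in an ADME assay on HEL cells (Homo sapiens) for cytotoxicity; on this read-out lower numbers stand for higher toxicity in this test and higher numbers for lower toxicity in this test. Compound 1 `O=C(COc1cccc2ccccc12)N/N=C/c1ccc(O)cc1` gives 60.6 ug/mL, the highest of the three numbers. Compound 2 `COc1cc(/C=N/NC(=O)COc2cccc3ccccc23)cc(OC)c1OC` gives 47.9 ug/mL, a number that sits within the scatter of compound 1. Compound 3 `O=C(COc1cccc2ccccc12)N/N=C/c1c(O)ccc2ccccc12` gives 1.94 ug/mL, a gap from compound 1 that lies well beyond the scatter.

Compound 4 `Cc1ccc(/C=N/NC(=O)COc2cccc3ccccc23)cc1` differs from compound 1 in a single place: methyl in place of hydroxy on an aromatic carbon. Going by the values given here, no measured pair shows this particular change, so its size can only be estimated. The comparison of compound 1 with compound 2, which differ only in what sits on that ring and still fall within the scatter of each other, suggests that substituents on this ring move the number little, while compound 3 shows that a change elsewhere in the molecule can move it far. A small step toward a lower number, or none beyond the scatter, is expected.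

Compound 4 is therefore expected to give 40 ug/mL, with a range from 15 ug/mL to 100 ug/mL. This estimate implies a step of a 1.5-fold lower number from compound 1 to compound 4 (0.18 log units; within the scatter) that is expected to stay close to the scatter.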

Compound 4, half-maximal cytotoxic concentration: 80.1 ug/mL
Compound 4: the middle estimate sits 2.0-fold (0.30 log units) below what was measured; the range from low to high includes it.
By their numbers in this assay, from the lowest: compound 3; then compounds 2, 1 and 4 (each within the scatter of the next).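

In this assay, exchanging 4-hydroxyphenyl for 4-methylphenyl gives a 1.3-fold higher number from compound 1 to compound 4 (0.12 log units; within the scatter), so a hydroxy on this aromatic carbon, para to a large group, can give way to a methyl without the number moving beyond the scatter. Going by these compounds alone, the exchange removes the hydrogen-bond donor and the hydrogen-bond acceptor that the hydroxy carries, and this is the first step between two compounds that differ in only one place, so this position now has a direct reading rather than an inference. Nothing measured here explains why the number holds across this exchange.

Within the data shown here, this single step covers only one exchange at one position, so an amine, a carboxylic acid or a longer chain such as propyl in the same place could behave quite differently. What lies behind the low number of compound 3, at 1.94 ug/mL, also stays open, as no compound shown connects it to the others through a change in one place.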